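This account rests on a few compounds, and the source may have more. Where it says the series, first, only, none or still open, it means among the compounds named here.

Measured compounds:

Compound 1, `COC(=O)N1CCC(Oc2ncnc3c2CCN3c2ccc(S(C)(=O)=O)cc2F)CC1`: in a functional assay on CHO-K1 cells with Glucose-dependent insulinotropic receptor (Homo sapiens) as the target, read by a luciferase reporter, with a stated time of 5 h (a higher number here means a larger maximal response, a lower number a smaller maximal response), compound 1 gives 119%.
Compound 2, `COCCOC(=O)N1CCC(Oc2ncnc3c2CCN3c2ccc(S(C)(=O)=O)cc2F)CC1`: compound 2 gives 86%.
Compound 3, `CS(=O)(=O)c1ccc(N2CCc3c(OC4CCN(C(=S)Sc5ccccc5)CC4)ncnc32)c(F)c1`: compound 3 gives 103%.

Compound 3 stands second highest of the three numbers. Its nearest neighbour is compound 1, with a number 16 percentage points lower from compound 1 to compound 3 (beyond the scatter); its furthest is compound 2, with a number 17 percentage points higher from compound 2 to compound 3 (beyond the scatter). Both of these steps alter the group on the amine nitrogen in the ring and both are modest, so the numbers move only moderately when that group is exchanged.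

Compound 4, `CC(C)S(=O)(=O)N1CCC(Oc2ncnc3c2CCN3c2ccc(S(C)(=O)=O)cc2F)CC1`, has not yet been measured. It differs from compound 3 as follows: a group of 6 heavy atoms (3 carbon, 2 oxygen, 1 sulfur; no ring) in place of a group of 9 heavy atoms (7 carbon, 2 sulfur; one six-membered aromatic ring of carbon only), on an amine nitrogen in a ring. Because a number 16 percentage points lower from compound 1 to compound 3 (beyond the scatter) and a number 17 percentage points higher from compound 2 to compound 3 (beyond the scatter) are both modest and point in opposite directions, a modest step in either direction, or none beyond the scatter, is expected in this assay for compound 4. The estimate for compound 4 is therefore 100%, with a range from 80% to 120%, which means an expected step of a number 3 percentage points lower from compound 3 to compound 4 (within the scatter).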

Compound 4, largest response reached (reported as percent of maximum), in percent of the reference or control that the assay uses: 62%
For compound 4 the middle estimate is 38 percentage points above the measured one, and the stated range ends above it.
By their numbers in this assay, from the lowest: compound 4; then compound 2; then compound 3; then compound 1.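

In this assay, isopropylsulfonyl on the amine nitrogen gives the lowest number of the four compounds, with a number 41 percentage points lower from compound 3 to compound 4 (beyond the scatter) and a number 24 percentage points lower from compound 2 to compound 4 (beyond the scatter). Among the compounds shown here, exchanging methoxycarbonyl directly for isopropylsulfonyl gives a number 57 percentage points lower from compound 1 to compound 4 (beyond the scatter), the largest step seen so far at this position, which shows that the group on this nitrogen can change the maximal response far more than the earlier compounds indicated. No measurement shown accounts for this drop.

The compounds shown leave open whether the lower number goes with the sulfonyl link or with the isopropyl carried on it, and methylsulfonyl or phenylsulfonyl on this nitrogen would help to separate the two. An isopropoxycarbonyl group, which places isopropyl on a carbonyl link instead, would test the same question from the other side.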